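Chloro for Methyl on Two Different Aromatic Positions

The compounds below may be only part of what the source reports. "The series", "measured", "known", "first", "only" and "open" are said of these compounds alone.

Measured in a functional assay on the whole organism (Cricetulus griseus) with Cricetinae gen. sp. as the target; on this read-out higher numbers stand for an effect only at larger amounts of compound and lower numbers for an effect already at smaller amounts:
compound 1, `Cc1cc(Cl)ccc1-c1n[nH]c(-c2ccccc2)n1`: 0.14 mg/kg
compound 2, `Cc1ccc(-c2n[nH]c(-c3ccccc3)n2)c(C)c1`: 0.2 mg/kg
compound 3, `Cc1ccccc1-c1n[nH]c(-c2ccccc2C)n1`: 0.7 mg/kg

Compound 3 stands highest of the three in this assay; the gap to compound 2 lies beyond the scatter. How the core of compound 3 differs from that of compound 2 is not broken down here.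

The change chloro in place of methyl on an aromatic carbon gave a 1.4-fold lower number from compound 2 to compound 1 (0.15 log units; within the scatter). Compound 4, `Cc1ccccc1-c1n[nH]c(-c2ccccc2Cl)n1`, is not yet measured; it arises from compound 3 by chloro in place of methyl on an aromatic carbon. This is the same kind of change, not the same: in compound 1 the chloro sits meta to a methyl group and para to a large group, in compound 4 ortho to a large group. Because the step of a 1.4-fold lower number from compound 2 to compound 1 (0.15 log units; within the scatter) was small, a similarly small step a 1.4-fold lower number from compound 3 to compound 4 (0.15 log units; within the scatter) is expected. Compound 4 is therefore estimated at 0.5 mg/kg, between 0.25 mg/kg and 1.2 mg/kg.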

Compound 4, dose for half-maximal effect: 15 mg/kg
The estimate for compound 4 lay 30-fold (1.48 log units) below the measured number; the measured number lies above the stated range.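

In this assay, chloro in place of methyl on an aromatic carbon gave a 21-fold higher number from compound 3 to compound 4 (1.33 log units; beyond the scatter), so the step seen on one core did not carry over to the other: the same change on two cores in this assay, a 1.4-fold lower number (0.15 log units; within the scatter) from compound 2 to compound 1 and a 21-fold higher number (1.33 log units; beyond the scatter) from compound 3 to compound 4, 31-fold (1.49 log units) apart, beyond the scatter of two such steps. The size of this change in the series therefore cannot be taken from one core and applied to another. The two pairs differ both in the core and in the place of the change, and they do not show which of these separates the steps.

The compounds shown leave open whether chloro ortho to a large group would give a step this large on the core of compound 2. They also leave open how fluoro, methoxy or an amine would behave at the place changed in compound 4.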